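Swapping the End Phenyl of Compound 3 for Fluoro

This account rests on a few compounds, and the source may have more. Where it says the series, first, only, none or still open, it means among the compounds named here.

In a functional assay on KB 3-1 cells (Homo sapiens) for cytotoxicity, read by MTT assay, with a stated time of 68 h (on this read-out higher numbers stand for weaker inhibition and lower numbers for stronger inhibition), compound 3 `O=C(Nc1cccc(-c2ccc(-c3ccccc3)cc2)c1)C(Cl)Cl` gives > 50000 nM, which is a limit of the assay and not a number. Compound 1 `O=C(Nc1cccc(-c2ccsc2)c1)C(Cl)Cl` gives > 50000 nM, also a limit. Among the compounds with values here, compound 2 `CCOc1ccccc1-c1cc(NC(=O)C(Cl)Cl)cc(-c2ccccc2OCC)c1` is the only one with a true number, 8730 nM. Compound 4 `O=C(Nc1cccc(-c2ccc(F)cc2)c1)C(Cl)Cl` carries fluoro in place of phenyl on an aromatic carbon, para to a large group (fluoro in place of phenyl on an aromatic carbon). Within the data shown here, no measured pair shows the effect of this swap. In this assay no step beyond the usual scatter is expected, and another limit reading is quite likely. The estimated change is small, an at least 1.1-fold lower number from compound 3 to compound 4 (0.04 log units; that floor lies within the scatter). For compound 4 the expected value is 45000 nM, with an estimated range of 20000 nM to 90000 nM.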

Compound 4, half-maximal inhibitory concentration: 26200 nM
The estimate for compound 4 lay 1.7-fold (0.23 log units) above the measured number, and the stated range covers the measured number.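

With fluoro in place of phenyl on this aromatic carbon, this assay gives a true number for compound 4, whereas compound 3 has only a limit. The change is an at least 1.9-fold lower number from compound 3 to compound 4 (0.28 log units; that floor lies within the scatter), so the true gap may be larger, but this floor alone does not establish a real change. Firm comparisons are scarce in this set because many readings rest on one ceiling: the limit of > 50000 nM in this assay, at which 2 of the 4 values shown sit.

Still open, from the compounds shown here alone, is whether an amine, a methoxy group or a carboxylic acid on this carbon would give a true number like that of compound 4 or return to the limit.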